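The source may hold more compounds than are shown below. What is called first, only, known or untested is meant among the compounds shown, and "the series" means these compounds.

In an assay on membranes from brain for displacement of a labelled ligand from Sigma non-opioid intracellular receptor 1 (Cavia porcellus), read by scintillation counting, with a stated time of 120 min (a higher number here means a weaker inhibitor, a lower number a stronger inhibitor), the three measured compounds gave the following numbers:

Compound 1 `CCCCN1CCN(CCC(=O)Nc2nc3c(C)cccc3s2)CC1`: 204 nM
Compound 2 `Cc1cccc2sc(NC(=O)CCN3CCN(CC4CCCO4)CC3)nc12`: 109 nM
Compound 3 `Cc1cccc2sc(NC(=O)CCN3CCN(C4CCCCC4)CC3)nc12`: 24 nM

Compound 3 stands lowest of the three, and both of its gaps to the others lie beyond the scatter: an 8.5-fold lower number from compound 1 to compound 3 (0.93 log units; beyond the scatter) and a 4.5-fold lower number from compound 2 to compound 3 (0.66 log units; beyond the scatter). The step from compound 1 to compound 2 is smaller, a 1.9-fold lower number from compound 1 to compound 2 (0.27 log units; within the scatter), and lies within the scatter.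

Compound 4 `Cc1cccc2sc(NC(=O)CCN3CCN(c4ncccn4)CC3)nc12` differs from compound 3 in one place: pyrimidin-2-yl in place of cyclohexyl on an amine nitrogen in a ring. For the measured compounds named here, none of the measured steps exchanges a saturated ring for an aromatic one on that nitrogen, so they bear only indirectly. What they do show is that the cyclohexyl group on that nitrogen in compound 3 gave the lowest number, and that the two other groups tried there, butyl in compound 1 and (oxolan-2-yl)methyl in compound 2, gave higher numbers. Leaving the cyclohexyl group is therefore expected to move the number upward, by a modest step, a 3.3-fold higher number from compound 3 to compound 4 (0.52 log units; beyond the scatter). Compound 4 is estimated at 80 nM, with a range from 25 nM to 250 nM.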

Compound 4, inhibition constant: 505 nM
Compound 4: middle estimate off by 6.3-fold (0.80 log units), on the low side; measured number above the stated range.
By their numbers in this assay, from the lowest: compound 3; then compounds 2 and 1 (each within the scatter of the next); then compound 4.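

In this assay, cyclohexyl and pyrimidin-2-yl both put a six-membered ring of 6 heavy atoms on the amine nitrogen in a ring, yet the exchange is large (a 21-fold higher number from compound 3 to compound 4 (1.32 log units; beyond the scatter)), so ring size and heavy-atom count alone do not set the number at this position. Pyrimidin-2-yl also stands above both groups that carry no ring directly on that nitrogen (a 4.6-fold higher number from compound 2 to compound 4 (0.67 log units; beyond the scatter); a 2.5-fold higher number from compound 1 to compound 4 (0.39 log units; beyond the scatter)), which places it highest of the four groups, above even the open-chain butyl. Nothing measured here accounts for this result.

Going by these compounds, whether the higher number goes with the aromatic ring itself or with its two ring nitrogens stays open, and a phenyl group on that nitrogen would separate the two. A piperidin-4-yl group would likewise show whether a nitrogen in a saturated ring is tolerated there.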